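A few compounds are considered here, and "the series" means these few. Any claim that something is new, unique, unknown or untested is made for them only; others in the source may bear on it.

Measured so far in an assay on isolated protein for displacement of a labelled ligand from melanin-concentrating hormone receptor 1 (Homo sapiens); a higher number here means a weaker inhibitor, a lower number a stronger inhibitor:
- compound 1, `CCc1cc(N)c2cc(NC(=O)/C=C/c3ccc(C(F)(F)F)cc3)ccc2n1`: 1.2 nM
- compound 2, `CCCc1cc(NC2CCC2)c2cc(NC(=O)/C=C/c3ccc(C(F)(F)F)cc3)ccc2n1`: 18 nM

Compound 1 holds the lowest of the two numbers in this assay. Compound 2 stands at a higher number, a gap beyond the scatter, but compound 2 differs from compound 1 in more than one respect, so the two values show only that the combined alteration weakens binding; no single change can be read from them.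

Compound 3, `Nc1cc(C2CCC2)nc2ccc(NC(=O)/C=C/c3ccc(C(F)(F)F)cc3)cc12`, is the next compound to be measured in this assay. It differs from compound 1 in a single respect: cyclobutyl in place of ethyl on an aromatic carbon. For the measured compounds named here, no measured pair differs by that one change alone.

Going by the values given here, with no single-change step to lean on, the expectation for compound 3 is a modest weakening relative to compound 1, estimated as a step of a 2.5-fold higher number from compound 1 to compound 3 (0.40 log units; beyond the scatter) in this assay. On that basis compound 3 is expected to give about 3 nM in this assay, within a range from 1 nM to 12 nM.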

Compound 3, half-maximal inhibitory concentration: 2 nM
Beside the measured number, compound 3's estimate is 1.5-fold (0.18 log units) above it, and the stated range covers the measured number.
By their numbers in this assay, from the lowest: compounds 1 and 3 (each within the scatter of the next); then compound 2.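

In this assay, placing cyclobutyl (4 heavy atoms, one four-membered ring) in place of ethyl (2 heavy atoms, no ring) on the aromatic carbon next to the ring nitrogen gives a 1.7-fold higher number from compound 1 to compound 3 (0.22 log units; within the scatter) and so leaves the two compounds indistinguishable in this assay. This is the only single-change step in the series shown, whereas compound 2 differs from compound 1 in more than one respect and isolates no change, so this position now has direct support for accepting a larger carbon group with a ring, at least for this one replacement. No measurement shown bears on why the step is this small.

A single replacement does not define the limit at this aromatic carbon, so a phenyl ring, a longer chain or a chain ending in an amine there remains untested in the compounds shown. The separate effect of a cyclobutylamino group in place of the amino group also stays open, since no pair shown isolates that change from the alkyl difference at the other position.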